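Adding a methyl to the cyclopropyl of compound 3

A few compounds are considered here, and "the series" means these few. Any claim that something is new, unique, unknown or untested is made for them only; others in the source may bear on it.

Among the measured compounds shown here, in a functional assay on the whole organism with Rattus norvegicus as the target (a higher number here means that more compound is needed for the effect, a lower number that less compound is needed), compound 3 (`COC(=O)CC/C=C\CC[C@H]1C(=O)C[C@@H](O)[C@@H]1/C=C/C[C@@](C)(O)/C=C/C1CC1`) stands at 0.402 mg/kg as the lowest number so far. Compound 1 (`COC(=O)CC/C=C\CC[C@H]1C(=O)C[C@@H](O)[C@@H]1/C=C/CC(C)(O)CCC1CCCC1`) sits higher at 1.31 mg/kg on this scale. For compound 2 (`COC(=O)CC/C=C\CC[C@H]1C(=O)C[C@@H](O)[C@@H]1/C=C/C[C@@](C)(O)/C=C/C1=CCCCC1`) the reading of > 3.16 mg/kg is a limit and not a number. Compound 4 (`COC(=O)CC/C=C\CC[C@H]1C(=O)C[C@@H](O)[C@@H]1/C=C/C[C@@](C)(O)/C=C/C1(C)CC1`) differs from compound 3 by methyl in place of hydrogen on a saturated ring carbon, which turns cyclopropyl into 1-methylcyclopropyl. The measured steps of a 3.3-fold lower number from compound 1 to compound 3 (0.51 log units; beyond the scatter) and an at least 7.8-fold lower number from compound 2 to compound 3 (0.89 log units; beyond the scatter) both end at cyclopropyl, but each swaps a whole ring, more than one methyl does. The expected step is small and upward at a 1.4-fold higher number from compound 3 to compound 4 (0.14 log units; within the scatter) and stays within the scatter. Compound 4 is expected to fall between 0.18 mg/kg and 1.7 mg/kg in this assay with 0.55 mg/kg as the best estimate.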

Compound 4, dose for half-maximal effect: 1.34 mg/kg
Estimate against measurement, compound 4: 2.4-fold (0.39 log units) below, and the stated range covers the measured number.
By their numbers in this assay, from the lowest: compound 3; then compounds 1 and 4 (each within the scatter of the next). At a limit, above all of these: compound 2.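

In this assay, a single methyl on a saturated ring carbon of the three-membered ring gives a 3.3-fold higher number from compound 3 to compound 4 (0.52 log units; beyond the scatter), so even one added carbon counts at this position. With that methyl in place, the step of a 1.0-fold higher number from compound 1 to compound 4 (0.01 log units; within the scatter) removes the gap that separated compound 3 from compound 1. The reading for compound 2 is a limit and not a number, so an at least 2.3-fold lower number from compound 2 to compound 4 (0.37 log units; beyond the scatter) is only a bound: the limit of > 3.16 mg/kg in this assay, at which 1 of the 4 values shown sits.

Going by these compounds, whether an ethyl or a fluorine on the same ring carbon would act like the methyl remains open.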